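Methyl for bromo: expectation for compound 3

The compounds below may be only part of what the source reports. "The series", "measured", "known", "first", "only" and "open" are said of these compounds alone.

Among the measured compounds shown here, in a functional assay on A-431 cells (Homo sapiens) for antiproliferative activity, read by sulforhodamine B assay, with a stated time of 72 h (a lower number here means a stronger inhibitor, a higher number a weaker inhibitor), compound 2 `C=C(Br)C(=O)Nc1cc(Nc2nccc(-c3cn(C)c4ccccc34)n2)c(OC)cc1N(C)CCN(C)C` gives 1060 nM as the lower of the two numbers so far, and compound 1 `C/C=C/C(=O)Nc1cc(Nc2nccc(-c3cn(C)c4ccccc34)n2)c(OC)cc1N(C)CCN(C)C` gives 5790 nM as the higher. Compound 3 `C=C(C)C(=O)Nc1cc(Nc2nccc(-c3cn(C)c4ccccc34)n2)c(OC)cc1N(C)CCN(C)C` carries methyl in place of bromo on a double-bonded chain carbon bound to a carbonyl carbon. For the measured compounds named here, compound 3 lacks bromo as compound 1 does, so the one measured step (a 5.5-fold lower number from compound 1 to compound 2 (0.74 log units; beyond the scatter)), modest but beyond the scatter, bears on this change. In this assay a step of similar size toward a higher number is expected (a 3.8-fold higher number from compound 2 to compound 3 (0.58 log units; beyond the scatter)). The estimated value for compound 3 is 4000 nM with an expected range (1500 nM to 10000 nM).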

Compound 3, half-maximal inhibitory concentration: 5340 nM
For compound 3 the middle estimate is 1.3-fold (0.13 log units) below the measured one; the range from low to high includes it.
By their numbers in this assay, from the lowest: compound 2; then compounds 3 and 1 (each within the scatter of the next).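

In this assay the direct comparison of bromo and methyl on a double-bonded chain carbon bound to a carbonyl carbon gives a clear separation (a 5.0-fold higher number from compound 2 to compound 3 (0.70 log units; beyond the scatter)). Replacing prop-1-en-1-yl with 1-methylethenyl on a carbonyl carbon gives none (a 1.1-fold lower number from compound 1 to compound 3 (0.04 log units; within the scatter)), so among these three groups only 1-bromoethenyl stands apart. No available measurement accounts for this difference. Still open, as far as these compounds go, is whether chloro or a dimethylaminomethyl group in the place of bromo would give a number nearer that of compound 2 or that of compound 3.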